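A few compounds are considered here, and "the series" means these few. Any claim that something is new, unique, unknown or untested is made for them only; others in the source may bear on it.

Three compounds share a core and were measured in a functional assay on brain (Rattus norvegicus, strain Wistar) for inhibition; on this read-out lower numbers stand for stronger inhibition and higher numbers for weaker inhibition. Compound 1 `Cc1[nH]c(=O)n(C)c1-c1ccc(OCc2ccccc2)cc1` gives 6700 nM, compound 2 `CCCc1ccc(-c2c(C)[nH]c(=O)n2C2CCCCC2)cc1` gives 13900 nM, and compound 3 `CCCCCCOc1ccc(-c2c(C)[nH]c(=O)n2C2CCCCC2)cc1` gives 8500 nM, the second highest of the three numbers; the values of compound 3 and compound 1 lie within the scatter of each other. Among the measured compounds shown here, the only single-point step recorded, a 1.6-fold lower number from compound 2 to compound 3 (0.21 log units; within the scatter), concerns a different change. Compound 4 `Cc1[nH]c(=O)n(C2CCCCC2)c1-c1ccc(OCc2ccccc2)cc1` differs from compound 3 by phenyl in place of pentyl on a saturated chain carbon bound to an oxygen on an aromatic ring. For the measured compounds named here, no measured step tests this change; compound 1 carries the same benzyloxy group and its value against compound 3 shows no gap beyond the scatter. He therefore expects for compound 4 a step of a 1.1-fold lower number from compound 3 to compound 4 (0.05 log units; within the scatter), not beyond the scatter. His estimate for compound 4 in this assay is 7500 nM, within a range from 3000 nM to 18000 nM.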

Compound 4, half-maximal inhibitory concentration: 8300 nM
Beside the measured number, compound 4's estimate is 1.1-fold (0.04 log units) below it, within the range that was stated.
By their numbers in this assay, from the lowest: compounds 1, 4, 3 and 2 (each within the scatter of the next, the first and the last beyond it).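

In this assay, the exchange of hexyloxy for benzyloxy makes no difference beyond the scatter: a 1.0-fold lower number from compound 3 to compound 4 (0.01 log units; within the scatter), so an aromatic phenyl in place of pentyl on this chain carbon is tolerated. The other steps are also within the scatter: a 1.7-fold lower number from compound 2 to compound 4 (0.22 log units; within the scatter), with benzyloxy in place of propyl, and a 1.2-fold higher number from compound 1 to compound 4 (0.09 log units; within the scatter), with cyclohexyl in place of methyl on the aromatic nitrogen. No measurement available here offers an explanation for these results. What the compounds shown leave open is whether an amine or a carboxylic acid at this place would shift the number beyond the scatter.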